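Chalcone series: chloro to methyl on the hydroxyphenyl ring

This account rests on a few compounds, and the source may have more. Where it says the series, first, only, none or still open, it means among the compounds named here.

compound 1 `Cc1nc(C)c(-c2nn(-c3ccc(F)cc3)cc2/C=C/C(=O)c2cc(Br)ccc2O)s1`: 4.88 ug/mL
compound 2 `Cc1nc(C)c(-c2nn(-c3ccc(F)cc3)cc2/C=C/C(=O)c2cc(Cl)ccc2O)s1`: > 250 ug/mL

In an ADME assay on HeLa cells (Homo sapiens) for inhibition, read by MTT assay (on this read-out higher numbers stand for weaker inhibition of growth and lower numbers for stronger inhibition of growth), compound 1 gives 4.88 ug/mL. For compound 2 the result is a limit of the assay, > 250 ug/mL, not a number. Compound 2 therefore sits at the limit of > 250 ug/mL in this assay, at which 1 of the 2 values shown sits, and only a limit is known for it. Within the data shown here, the one measured step, an at least 51-fold higher number from compound 1 to compound 2 (1.70 log units; beyond the scatter), was large. Compound 3 `Cc1ccc(O)c(C(=O)/C=C/c2cn(-c3ccc(F)cc3)nc2-c2sc(C)nc2C)c1` differs from compound 2 by methyl in place of chloro on an aromatic carbon. Among the measured compounds shown here, no measured step changes chloro to methyl, and compound 2 already stands at a limit, so for compound 3 the expected step in this assay is an at least 1.6-fold lower number from compound 2 to compound 3 (0.22 log units; that floor lies within the scatter), with a limit again the likeliest outcome. Compound 3 is expected at 150 ug/mL, in a range from 20 ug/mL to 250 ug/mL.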

Compound 3, concentration for 50% growth inhibition: 29.9 ug/mL
Estimate against measurement, compound 3: 5.0-fold (0.70 log units) above; low and high end bracket the measured number.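

At the position para to the hydroxy group, methyl gives a measured growth inhibition where chloro did not in this assay, with an at least 8.3-fold lower number from compound 2 to compound 3 (0.92 log units; beyond the scatter). Methyl does not match bromo, with a 6.1-fold higher number from compound 1 to compound 3 (0.79 log units; beyond the scatter), so the three groups at this position run bromo, methyl, chloro from lower to higher number. The result for compound 2 is a limit of the assay and not a number: the limit of > 250 ug/mL in this assay, at which 1 of the 3 values shown sits.

The compounds shown leave open where fluoro, methoxy or an amine at this position would fall in that order. They also leave open whether an ethyl group would read like methyl.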